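Compound 2 to compound 4: a side-chain swap

The compounds below may be only part of what the source reports. "The series", "measured", "known", "first", "only" and "open" are said of these compounds alone.

Measured in a functional assay on MDA-MB-231 cells (Homo sapiens) for inhibition; on this read-out higher numbers stand for weaker inhibition and lower numbers for stronger inhibition:
- compound 1 `O=C(NO)c1ccc(-c2ccc(CNCc3ccccc3Cl)cn2)s1`: 170 nM
- compound 2 `O=C(NO)c1ccc(-c2ccc(CNCc3ccc(Cl)cc3)cn2)s1`: 300 nM
- compound 3 `CN(Cc1ccccc1)Cc1ccc(-c2ccc(C(=O)NO)s2)nc1`: 370 nM

Compound 2, at 300 nM, lies within the scatter of both compound 1 and compound 3. Compound 4 `O=C(NO)c1ccc(-c2ccc(CNCCOc3ccccc3)cn2)s1` is not yet measured. Its difference from compound 2 is phenoxymethyl in place of 4-chlorophenyl on a saturated chain carbon bound to an amine nitrogen, with phenoxymethyl in place of 4-chlorophenyl on a saturated chain carbon bound to an amine nitrogen. For the measured compounds named here, the one measured step at this place exchanges 2-chlorophenyl for 4-chlorophenyl: a 1.8-fold higher number from compound 1 to compound 2 (0.25 log units; within the scatter). Going by the values given here, no measured compound carries phenoxymethyl, so this step is only a loose guide. Among the compounds with values here, with a 1.8-fold higher number from compound 1 to compound 2 (0.25 log units; within the scatter) as the sole evidence, no step beyond the scatter is expected in this assay. The estimated step is a 1.1-fold lower number from compound 2 to compound 4 (0.03 log units; within the scatter). Compound 4 is expected at 280 nM, with an estimated range of 100 nM to 800 nM.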

Compound 4, half-maximal inhibitory concentration: 300 nM
Beside the measured number, compound 4's estimate is 1.1-fold (0.03 log units) below it, and the stated range covers the measured number.
By their numbers in this assay, from the lowest: compounds 1, 2, 4 and 3 (each within the scatter of the next, the first and the last beyond it).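

In this assay, the place on a saturated chain carbon bound to an amine nitrogen accepts more than chlorophenyl groups: phenoxymethyl gives no change at the digits printed from compound 2 to compound 4 (within the scatter), and a 1.8-fold higher number from compound 1 to compound 4 (0.25 log units; within the scatter). Removing the chlorine and adding an oxygen, with its hydrogen-bond acceptor, therefore moves no number beyond the scatter in these pairs. On these data alone, whether an amine or a carboxylic acid in place of phenoxymethyl would give a step beyond the scatter stays open. No measured property accounts for the result at this place.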